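The compounds below may be only part of what the source reports. "The series", "measured", "known", "first", "only" and "open" are said of these compounds alone.

Two compounds share one core and are measured in an ADME assay on MT4 cells (Homo sapiens) for cytotoxicity, read by MTT assay, with a stated time of 5 days; a higher number here means that more compound is tolerated, a lower number that less compound is tolerated. Compound 1 `O=C1N(Cc2ccccc2Cl)c2cccn2S(=O)(=O)N1Cc1cccc(F)c1` carries a fluoro group on one benzyl arm and a single chloro group on the other; in this assay compound 1 gives 231000 nM. Compound 2 `O=C1N(Cc2ccc(Cl)cc2Cl)c2cccn2S(=O)(=O)N1Cc1cccc(Br)c1` carries a bromo group on the first arm and two chloro groups on the second. In this assay compound 2 gives > 243000 nM, which is a limit of the assay rather than a measured number. Compound 2 therefore stands at the top of what this assay reports, as the limit of > 243000 nM in this assay, at which 1 of the 2 values shown sits, shows, with compound 1 sitting close to that same region.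

Compound 3 `O=C1N(Cc2ccc(Cl)cc2Cl)c2cccn2S(=O)(=O)N1Cc1cccc(F)c1` is not yet measured. It differs from compound 2 by fluoro in place of bromo on an aromatic carbon. Among the compounds with values here, no measured pair in this set shows what this particular change does in this assay, so the size of the step is uncertain. Given that compound 1, which carries the same fluoro group, gives 231000 nM, the step from compound 2 to compound 3 is expected to be an at least 1.0-fold lower number from compound 2 to compound 3 (0.00 log units; that floor lies within the scatter), that is, nothing beyond the usual scatter. Compound 3 is expected to give about 240000 nM, within 120000 nM to 500000 nM, and may again come back as a limit.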

Compound 3, half-maximal cytotoxic concentration: > 249000 nM
Compound 3 ended at the assay's limit; the forecaster's own chance of this, stated with the estimate: 60%; middle value at least 1.0-fold (0.01 log units) away from the limit.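

In this assay, fluoro in place of bromo on the 3-bromobenzyl arm gives two limits, so the step between compound 2 and compound 3 cannot be read, and nothing shows that this change lowers the amount of compound tolerated. Compound 3 gives > 249000 nM, which is a limit of the assay and not a number: the limit of > 249000 nM in this assay, at which 1 of the 3 values shown sits. Within the data shown here, the one change that can be read is chloro in place of hydrogen on an aromatic carbon, which gives an at least 1.0-fold higher number from compound 1 to compound 3 (0.03 log units; that floor lies within the scatter), so this added chloro group shows no loss in how much compound is tolerated.

The compounds shown leave open how far beyond their limits compound 2 and compound 3 truly lie, and so whether bromo and fluoro differ at all at this position. They also leave open whether a very different group on that arm, such as an amine or a carboxylic acid in place of the halogen, would bring the reading down to a measurable number.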